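A few compounds are considered here, and "the series" means these few. Any claim that something is new, unique, unknown or untested is made for them only; others in the source may bear on it.

Of the compounds shown here, two have been tested so far in a functional assay on PC-3 cells (Homo sapiens) for cytotoxicity, read by MTT assay, with a stated time of 48 h; a lower number here means a stronger inhibitor, a higher number a weaker inhibitor. Compound 1, with the structure `CC1=NN(C(=O)CCl)C(c2cc(Br)ccc2O)C1`, gives 8890 nM in this assay. Compound 2, with the structure `O=C(c1ccccc1)N1N=C(c2cc3ccccc3oc2=O)CC1c1ccccc1`, gives 5870 nM in this assay. Compound 2 has the lower of the two numbers, but the gap between them is within the usual scatter of repeated measurements, so the two cannot be told apart on this evidence.

Compound 3, with the structure `NC(=O)C1CCN(CC(=O)N2N=C(c3cc4ccccc4oc3=O)CC2c2ccccc2)CC1`, has not yet been measured in this assay. It differs from compound 2 in one place: (4-carbamoylpiperidin-1-yl)methyl in place of phenyl on a carbonyl carbon. Within the data shown here, no pair of measured compounds shows a change of this kind, so nothing among the measured numbers says how large a step to expect or in which direction. The safest expectation is therefore a step that does not go far beyond the scatter, with a slight lean toward a weaker inhibitor. The step from compound 2 that this means is expected to be a 1.4-fold higher number from compound 2 to compound 3 (0.13 log units; within the scatter). Compound 3 is estimated to give 8000 nM in this assay, most likely between 3000 nM and 25000 nM.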

Compound 3, half-maximal inhibitory concentration: 8310 nM
Compound 3: the middle estimate sits 1.0-fold (0.02 log units) below what was measured, within the range that was stated.
By their numbers in this assay, from the lowest: compounds 2, 3 and 1 (each within the scatter of the next).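

In this assay, among these compounds, putting (4-carbamoylpiperidin-1-yl)methyl in place of phenyl on the carbonyl carbon gives a 1.4-fold higher number from compound 2 to compound 3 (0.15 log units; within the scatter) and so gives the first reading of how this position responds to a change. The swap is a substantial one, as an aromatic ring of carbon only, with no hydrogen-bond donors or acceptors, gives way to a larger non-aromatic group that carries both, yet the two numbers cannot be told apart, so in this pair an aromatic ring directly on the carbonyl carbon is not required for activity at this level. No measurement of any property of either group is available to explain this outcome.

On these data alone, this is a single replacement, so it remains open whether any other group on the carbonyl carbon would move the number beyond the scatter in either direction. A plain methyl, a piperidine without the carbamoyl group, or a carboxylic acid in place of that carbamoyl group would each help show which part of the new group, if any, matters.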